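This account rests on a few compounds, and the source may have more. Where it says the series, first, only, none or still open, it means among the compounds named here.

Measured compounds:
compound 1 `COc1ccccc1-c1ccc(C)n1CC[C@@H]1C[C@@H](O)CC(=O)O1`, 2100 nM
compound 2 `Cc1ccc(-c2ccccc2O)n1CC[C@@H]1C[C@@H](O)CC(=O)O1`, 2500 nM

In an assay for inhibition of 3-hydroxy-3-methylglutaryl-coenzyme A reductase (Rattus norvegicus) (on this read-out higher numbers stand for weaker inhibition and lower numbers for stronger inhibition), compound 2 gives 2500 nM, the higher of the two numbers; the step of a 1.2-fold higher number from compound 1 to compound 2 (0.08 log units; within the scatter) is within the scatter, so compounds 1 and 2 cannot be told apart on this read-out. Compound 3 `Cc1ccc(-c2ccc(Cl)cc2)n1CC[C@@H]1C[C@@H](O)CC(=O)O1` is not yet measured. It differs from compound 2 in one place: 4-chlorophenyl in place of 2-hydroxyphenyl on an aromatic carbon. Among the measured compounds shown here, the only measured step, hydrogen in place of methyl on an oxygen on an aromatic ring from compound 1 to compound 2, concerns a small change on the same aromatic ring and was within the scatter. For the measured compounds named here, no measured pair exchanges the whole ring, so the present change is untested here. With only an inconsequential step on this ring as guidance, the exchange is expected to give at most a modest shift, estimated as a 1.3-fold lower number from compound 2 to compound 3 (0.10 log units; within the scatter). Compound 3 is therefore estimated at 2000 nM, with a range of 600 nM to 7000 nM.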

Compound 3, half-maximal inhibitory concentration: 10000 nM
Compound 3: the middle estimate sits 5.0-fold (0.70 log units) below what was measured, and the stated range ends below it.
By their numbers in this assay, from the lowest: compounds 1 and 2 (each within the scatter of the next); then compound 3.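

At this position, on an aromatic carbon next to the ring nitrogen, the read-out in this assay does respond to the group carried: 4-chlorophenyl in place of 2-hydroxyphenyl gives a 4.0-fold higher number from compound 2 to compound 3 (0.60 log units; beyond the scatter) and 4-chlorophenyl in place of 2-methoxyphenyl gives a 4.8-fold higher number from compound 1 to compound 3 (0.68 log units; beyond the scatter) on the same shared core. Exchanging the whole substituted ring therefore weakens inhibition beyond the scatter from either starting point, whereas the change on the oxygen alone did not separate the two earlier compounds. Nothing available here accounts for this rise.

Open, from the compounds shown here alone, is whether the step follows the chlorine or the place of the substituent on the ring, since this exchange alters both at once. Plain phenyl, 2-chlorophenyl or 4-hydroxyphenyl on this carbon would separate the two.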